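Loss of the fluoro group in two related cores

The source may report more compounds than this note shows. Statements on the series, on what has been measured and on what is new or still open speak of the compounds shown alone.

Compound 1 `COc1cccc(CNCc2c(-c3nnc(SC(C)C)n3-c3ccccc3)n(C)c3ccc(F)cc23)c1` is the reference. In a physicochemical assay for lipophilicity (a lower number here means a more polar compound, a higher number a more lipophilic compound), compound 1 gives 6.42. Compound 2 `COc1cccc(CNCc2c(-c3nnc(SC(C)C)n3-c3ccccc3)n(C)c3ccccc23)c1` differs from it by hydrogen in place of fluoro on an aromatic carbon; in this assay compound 2 gives 6.27, so the step of a number 0.15 log units lower from compound 1 to compound 2 (within the scatter). Compound 3 `CC(C)Sc1nnc(-c2c(CNCCN3CCCC3)c3cc(F)ccc3n2C)n1-c1ccccc1` carries a different side chain, the change being ((pyrrolidin-1-yl)methyl in place of 3-methoxyphenyl on a saturated chain carbon bound to an amine nitrogen); in this assay compound 3 gives 4.99, and the step of a number 1.43 log units lower from compound 1 to compound 3 (beyond the scatter). Compound 3 thus holds the lowest of the three numbers, with compound 2 nearest and compound 1 furthest, both beyond the scatter.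

Compound 4 `CC(C)Sc1nnc(-c2c(CNCCN3CCCC3)c3ccccc3n2C)n1-c1ccccc1` is not yet measured. It stands to compound 3 as compound 2 stands to compound 1: the change is hydrogen in place of fluoro on an aromatic carbon, the same kind of change as between compound 1 and compound 2, at a place described in the same words. For the measured compounds named here, the one comparable pair measured so far is compound 1 to compound 2, where the step of a number 0.15 log units lower from compound 1 to compound 2 (within the scatter) in this assay. The step from compound 3 to compound 4 is therefore expected to be a number 0.15 log units lower from compound 3 to compound 4 (within the scatter), small and within the scatter. Taking compound 3 at 4.99 as the anchor, compound 4 is estimated to reach 4.84 in this assay. Going by the values given here, for compound 4 the range is expected to run from 4.5 to 5.2, kept open since only one earlier pair supports the expectation.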

Compound 4, partition coefficient: 4.83
Beside the measured number, compound 4's estimate is 0.01 log units above it, within the range that was stated.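

Hydrogen in place of fluoro on the aromatic carbon gives the same reading in both side-chain settings: in this assay the change is a number 0.16 log units lower from compound 3 to compound 4 (within the scatter) with the (pyrrolidin-1-yl)methyl group present and a number 0.15 log units lower from compound 1 to compound 2 (within the scatter) with the 3-methoxyphenyl group present, so in these two pairs the change carries over without a step beyond the scatter. The side-chain change carries over likewise, at a number 1.44 log units lower from compound 2 to compound 4 (beyond the scatter) in the compounds without fluoro and a number 1.43 log units lower from compound 1 to compound 3 (beyond the scatter) in those with it, both large and beyond the scatter, so within these four compounds the two changes read as independent of each other. This rests on two pairs for each change, shows no fluoro effect distinguishable from repeat scatter, and says nothing about other cores or other read-outs, and no measurement here offers an explanation for either step.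

Still open, as far as these compounds go, is whether chloro or nitrile on the same aromatic carbon would also stay within the scatter in both side-chain settings. Equally open, from the compounds shown here alone, is whether a piperidine or morpholine in place of the pyrrolidine, or a longer chain to the amine, would keep the fluoro-to-hydrogen step unchanged.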